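Amide-side variation on the shared core

The compounds below may be only part of what the source reports. "The series", "measured", "known", "first", "only" and "open" are said of these compounds alone.

Compound 1 `CCn1c(C(=O)NCCO)ccc1C(CC)(CC)c1ccc(OCS(=O)(=O)c2ccccc2)c(C)c1` gives 19900 nM in a functional assay on BXPC-3 cells (Homo sapiens) for antiproliferative activity, read by MTT assay, with a stated time of 24 h; on this read-out lower numbers stand for stronger inhibition and higher numbers for weaker inhibition; of the two numbers measured this is the higher, with compound 2 `CCn1c(C(=O)N[C@@H](C(=O)O)C(C)C)ccc1C(CC)(CC)c1ccc(OCS(=O)(=O)c2ccccc2)c(C)c1` nearest at 13900 nM in this assay. The step of a 1.4-fold lower number from compound 1 to compound 2 (0.16 log units; within the scatter) is the only one that bears on the change now considered, and it stays within the scatter. Compound 3 `CCn1c(C(=O)N[C@H](CC(=O)O)C(=O)O)ccc1C(CC)(CC)c1ccc(OCS(=O)(=O)c2ccccc2)c(C)c1` differs from compound 1 by 1,2-dicarboxyethyl in place of 2-hydroxyethyl on an amide-type nitrogen. Because a 1.4-fold lower number from compound 1 to compound 2 (0.16 log units; within the scatter) showed no movement beyond the scatter for a carboxy-bearing group, compound 3 is expected to give a 1.2-fold lower number from compound 1 to compound 3 (0.09 log units; within the scatter). Compound 3 is therefore estimated at 16000 nM, with a range from 6500 nM to 40000 nM.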

Compound 3, half-maximal inhibitory concentration: > 50000 nM
Compound 3: only a limit was reported; the forecaster's own chance of this, stated with the estimate: 10%; at least 3.1-fold (0.49 log units) between middle value and limit.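

In this assay compound 3 is reported only as a limit, not as a number: the limit of > 50000 nM in this assay, at which 1 of the 3 values shown sits. Within the data shown here, the amide-type nitrogen is therefore not indifferent to its substituent: 1,2-dicarboxyethyl in place of 2-hydroxyethyl gives an at least 2.5-fold higher number from compound 1 to compound 3 (0.40 log units; beyond the scatter), the first step beyond the scatter. Carboxymethyl in place of isopropyl on the saturated chain carbon gives an at least 3.5-fold higher number from compound 2 to compound 3 (0.55 log units; beyond the scatter), so the two carboxy-bearing groups do not read alike.

Going by these compounds, the actual value of compound 3 remains unknown. Also open, on these data alone, is whether the shift follows the carboxymethyl group itself or the loss of isopropyl, which a 2-aminoethyl or 2-carboxyethyl group on the same nitrogen could help separate.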